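Phenyl to butyl on the ester carbonyl

The compounds below may be only part of what the source reports. "The series", "measured", "known", "first", "only" and "open" are said of these compounds alone.

- compound 1 `C=C1CC[C@@H]2[C@](C)(CO)[C@H](OC(=O)c3cccnc3)CC[C@@]2(C)[C@@H]1C/C=C1\C=COC1=O` gives 337000 nM
- compound 2 `C=C1CC[C@@H]2[C@](C)(CO)[C@H](OC(=O)c3ccco3)CC[C@@]2(C)[C@@H]1C/C=C1\C=COC1=O` gives 42000 nM
- compound 3 `C=C1CC[C@@H]2[C@](C)(CO)[C@H](OC(=O)c3ccccc3)CC[C@@]2(C)[C@@H]1C/C=C1\C=COC1=O` gives 103000 nM

Compound 3 stands second highest of the three in an ADME assay on HepG2 2.2.15 cells (Homo sapiens) for cytotoxicity, read by MTT assay; on this read-out higher numbers stand for lower toxicity in this test and lower numbers for higher toxicity in this test (a 2.5-fold higher number from compound 2 to compound 3 (0.39 log units; beyond the scatter); a 3.3-fold lower number from compound 1 to compound 3 (0.51 log units; beyond the scatter)). Going to compound 4 `C=C1CC[C@@H]2[C@](C)(CO)[C@H](OC(=O)CCCC)CC[C@@]2(C)[C@@H]1C/C=C1\C=COC1=O` puts butyl in place of phenyl on a carbonyl carbon. Among the compounds with values here, three measured steps bear on this, all modest and beyond the scatter, each swapping one ring group for another (an 8.0-fold lower number from compound 1 to compound 2 (0.90 log units; beyond the scatter); a 3.3-fold lower number from compound 1 to compound 3 (0.51 log units; beyond the scatter); a 2.5-fold higher number from compound 2 to compound 3 (0.39 log units; beyond the scatter)). No open-chain group has been measured at this place, so the direction is unclear, and no step beyond the scatter is expected in this assay here. The estimate for compound 4 is 80000 nM (range 27000 nM to 240000 nM). The expected change is small (a 1.3-fold lower number from compound 3 to compound 4 (0.11 log units; within the scatter)).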

Compound 4, half-maximal cytotoxic concentration: 126000 nM
Compound 4: the middle estimate sits 1.6-fold (0.20 log units) below what was measured; measured number inside the range.
By their numbers in this assay, from the lowest: compound 2; then compounds 3 and 4 (each within the scatter of the next); then compound 1.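

In this assay, replacing the ring on this carbonyl carbon with an open chain leaves the number within the scatter (a 1.2-fold higher number from compound 3 to compound 4 (0.09 log units; within the scatter)), so an aromatic ring is not required to reach this level. Butyl still stands apart from both ring groups containing a heteroatom, in opposite directions (a 3.0-fold higher number from compound 2 to compound 4 (0.48 log units; beyond the scatter); a 2.7-fold lower number from compound 1 to compound 4 (0.43 log units; beyond the scatter)), leaving furan-2-yl and pyridin-3-yl on either side of the phenyl and butyl pair. Nothing available bears on the cause of these differences.

Open, going by these compounds, is whether a longer chain or a branched chain such as tert-butyl would stay level with butyl. Also open, on these data alone, is whether an amine or a carboxylic acid on the chain would shift the number as pyridin-3-yl does.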